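Cytotoxicity of a cyclopropyl analogue: an expectation

The source may hold more compounds than are shown below. What is called first, only, known or untested is meant among the compounds shown, and "the series" means these compounds.

This set of compounds was examined in an ADME assay on Vero cells (Chlorocebus sabaeus) for cytotoxicity, read by CCK-8 assay, with a stated time of 72 h; on this read-out lower numbers stand for stronger inhibition and higher numbers for weaker inhibition. Compound 1, with the structure `COc1ccn2nc(C)c(C(=O)NCc3ccc(N4CCC(c5ccc(OC(F)(F)F)cc5)CC4)cc3)c2c1`, gives > 100000 nM in this assay, which is a limit of the assay rather than a measured number. Compound 2, with the structure `CCc1ccn2nc(C)c(C(=O)NCc3ccc(N4CCC(c5ccc(OC(F)(F)F)cc5)CC4)cc3)c2c1`, gives > 100000 nM, again a limit. The change a step that the two limits leave unreadable from compound 1 to compound 2 therefore cannot be sized. Compound 3, with the structure `O=C(NCc1ccc(N2CCC(c3ccc(OC(F)(F)F)cc3)CC2)cc1)c1cnn2ccc(Cl)cc12`, has "not determined" (no result reported) in this assay, so no number for it is known. Compound 4, with the structure `O=C(NCc1ccc(N2CCC(c3ccc(OC(F)(F)F)cc3)CC2)cc1)c1c(C2CC2)nn2ccc(Cl)cc12`, differs from compound 3 only by cyclopropyl in place of hydrogen on an aromatic carbon.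

Within the data shown here, no measured step bears on this change, and the single step that was measured is unreadable. What the data do show is the evidence (the limit of > 100000 nM in this assay, at which 2 of the 3 values shown sit), that is, the values found so far sit at the ceiling of the assay. On this basis compound 4 is expected to show weak cytotoxicity, most likely again reported only as a limit. The estimate for compound 4 in this assay is 100000 nM, with a range from 40000 nM to 300000 nM.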

Compound 4, half-maximal inhibitory concentration: > 100000 nM
Compound 4 ended at the assay's limit; the forecaster's own chance of this, stated with the estimate: 80%; the middle value sits exactly at the limit.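

No step can be read from compound 3 to compound 4: compound 3 has no reported result, and compound 4 gives only a limit of the assay, not a number. The compounds shown leave open what concentration would bring any of them to half-maximal inhibition in this assay.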